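This account rests on a few compounds, and the source may have more. Where it says the series, first, only, none or still open, it means among the compounds named here.

Of the compounds shown here, three that share one core have so far been tested in an ADME assay on microsomes from liver (Homo sapiens) for metabolic stability, read by LC-MS, using NADPH, with a stated time of 30 min, tested at 0.1 uM, in the presence of a further agent that is not named here; on this read-out higher numbers stand for a more stable compound and lower numbers for a less stable compound. Compound 1 `CS(=O)(=O)c1ccc(-c2cnc(N)c(-c3ccc(N)nc3)n2)cc1` gives a reading of > 90% in this assay, which is a limit of the measurement and not an exact number. Compound 3 `Nc1ccc(-c2cnc(N)c(-c3ccc(N)nc3)n2)cn1` likewise reaches > 90%, again a limit. Compound 2 `Nc1ncc(-c2ccc(C(=O)O)cc2)nc1-c1ccc(C(F)(F)F)cc1`, which carries a carboxy group, stands at > 90%, once more a limit rather than a figure. Going by the values given here, compound 2 thus sits exactly where every value so far sits, namely at the limit of > 90% in this assay, at which 3 of the 3 values shown sit, and nothing on these numbers sets it apart from the other two.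

Compound 4 `Nc1ncc(-c2ccc(C(=O)N3CC[C@H](O)C3)cc2)nc1-c1ccc(C(F)(F)F)cc1` is derived from compound 2 by a single change: 3-hydroxypyrrolidin-1-yl in place of hydroxy on a carbonyl carbon. Among the compounds with values here, no two measured compounds differ from each other in only one place, so no measured step shows how much such a change can move the reading. The expectation is therefore a small downward move at most, or none beyond the usual scatter. Compound 4 is expected to give about 85%, with a likely range from 60% to 95%. The estimated step is a number at least 5 percentage points lower from compound 2 to compound 4 (that floor lies within the scatter).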

Compound 4, percent of the compound remaining: > 90%
Compound 4 ended at the assay's limit; the forecaster's own chance of this, stated with the estimate: 50%; middle value at least 5 percentage points away from the limit.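

In this assay, compound 2 and compound 4 both give limits rather than exact numbers, so no step between them can be read: the limit of > 90% in this assay, at which 4 of the 4 values shown sit.

The compounds shown leave open how far carboxy to (3-hydroxypyrrolidin-1-yl)carbonyl, or any other change, moves the stability reading.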